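Urea series: carboxy for methylsulfanyl, solubility outlook

The source may report more compounds than this note shows. Statements on the series, on what has been measured and on what is new or still open speak of the compounds shown alone.

The series shares one urea core with a quinoline-type half, and the data so far cover two measured compounds. Compound 1 `CSc1ccc(NC(=O)Nc2cc(C)nc3ccccc23)cc1` carries a methylsulfanyl group on its aryl ring; in a physicochemical assay for solubility, at pH 7.4 (a lower number here means a less soluble compound, a higher number a more soluble compound), compound 1 gives 1300 nM. Compound 2 `COc1ccccc1NC(=O)Nc1cc(C)nc2ccccc12` carries a methoxy group instead, and in this assay compound 2 gives 100 nM. Compound 1 therefore holds the highest of the two numbers, and compound 2 stands a clear distance below it, beyond the scatter of the method.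

Compound 3 `Cc1cc(NC(=O)Nc2ccc(C(=O)O)cc2)c2ccccc2n1` has not yet been measured in this assay. Relative to compound 1 the change is carboxy in place of methylsulfanyl on an aromatic carbon. Going by the values given here, no step between measured compounds covers this change, so the expectation rests on the direction set by compound 1 alone. For compound 3 the step of a 9.2-fold higher number from compound 1 to compound 3 (0.97 log units; beyond the scatter) is expected to be a rise well beyond the scatter. Compound 3 is estimated at 12000 nM, within a range of 2500 nM to 60000 nM, pending the measurement.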

Compound 3, solubility: 9300 nM
For compound 3 the middle estimate is 1.3-fold (0.11 log units) above the measured one; the range from low to high includes it.
By their numbers in this assay, from the lowest: compound 2; then compound 1; then compound 3.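

In this assay the series now has its first step between compounds that differ in one place: carboxy in place of methylsulfanyl, on an aromatic carbon para to a large group, comes with a 7.2-fold higher number from compound 1 to compound 3 (0.85 log units; beyond the scatter) and lies beyond the scatter. This shows that the number in this assay responds to what sits at this position while the rest of compound 1 stays the same, which the earlier pair, differing in more than one place, could not show. The exchange swaps sulfur for two oxygens, adds one heavy atom and brings in a hydrogen-bond donor, and nothing measured here ties the step to any one of these differences.

A single step gives direction and size for one pair only, so it sets no trend for this position. A methyl ester, a primary amide or an amine in the same place would show whether the step belongs to carboxy alone or is shared by other groups, and a longer chain ending in carboxy would show whether the distance of that group from the aromatic ring matters.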